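Bromo to nitro at compound 4

A few compounds are considered here, and "the series" means these few. Any claim that something is new, unique, unknown or untested is made for them only; others in the source may bear on it.

In a functional assay on PANC-1 cells (Homo sapiens) for antiproliferative activity, read by fluorescence and resazurin assay, with a stated time of 48 h (a higher number here means a weaker inhibitor, a lower number a stronger inhibitor), compound 1 (`CCOc1ccc(NC(=O)c2cc3cc(Br)ccc3oc2=O)cc1`) gives 16800 nM, compound 2 (`CCOc1ccc2nc(Cl)c(/C=N/NC(=O)c3cc4ccccc4oc3=O)cc2c1`) gives 29900 nM and compound 3 (`O=C(N/N=C/c1ccncc1)c1cc2cc(Br)ccc2oc1=O`) gives 25700 nM. Compound 3 lies within the scatter of both other compounds, so the three values do not separate. Compound 4 (`O=C(N/N=C/c1ccncc1)c1cc2cc([N+](=O)[O-])ccc2oc1=O`) carries nitro in place of bromo on an aromatic carbon. Among the compounds with values here, no pair of measured compounds differs in one place only, so the series offers no direct measure of this change. No step beyond the scatter is expected in this assay, and neither direction is favoured. The expected change is a 1.1-fold lower number from compound 3 to compound 4 (0.03 log units; within the scatter). For compound 4 the estimated value is 24000 nM, with an expected range of 10000 nM to 55000 nM.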

Compound 4, half-maximal inhibitory concentration: 26100 nM
Compound 4: the middle estimate sits 1.1-fold (0.04 log units) below what was measured; measured number inside the range.
By their numbers in this assay, from the lowest: compounds 1, 3, 4 and 2 (each within the scatter of the next).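

In this assay, within the data shown here, the only single-place comparison gives a 1.0-fold higher number from compound 3 to compound 4 (0.01 log units; within the scatter), so nitro in place of bromo on this aromatic carbon does not separate compound 4 from compound 3. Replacing one bromine with the three heavy atoms of nitro, which adds two hydrogen-bond acceptors, therefore leaves the number within the scatter in this setting. No measurement available here offers an explanation for this result.

From the compounds shown here alone, it remains open whether an amine or a methoxy group at this position would give a step beyond the scatter. Going by these compounds, it also remains open whether nitro in place of bromo would behave alike in compound 1, which carries a different side chain.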